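The source may hold more compounds than are shown below. What is called first, only, known or untested is meant among the compounds shown, and "the series" means these compounds.

Compound 1, `O=C(Oc1ccc(-c2cncn2C2CCN(C(=O)c3ccc(Cl)c(C(F)(F)F)c3)CC2)cc1)c1ccccc1` — in an assay on HEK293 cells for antagonist activity at P2X purinoceptor 7 (Homo sapiens), read by fluorescence, with a stated time of 2 h (on this read-out higher numbers stand for weaker inhibition and lower numbers for stronger inhibition), compound 1 gives > 10000 nM, which is a limit of the assay and not a number.
Compound 2, `O=C(c1ccc(Cl)c(C(F)(F)F)c1)N1CCC(n2cncc2-c2ccc(OS(=O)(=O)c3cccs3)cc2)CC1` — in this assay compound 2 gives 238 nM.
Compound 3, `N#Cc1cccc(S(=O)(=O)Oc2ccc(-c3cncn3C3CCN(C(=O)c4ccc(Cl)c(C(F)(F)F)c4)CC3)cc2)c1` — in this assay compound 3 gives 73 nM.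

Compound 3 stands lowest of the two numbers shown; compound 2 is nearest to it, with a 3.3-fold lower number from compound 2 to compound 3 (0.51 log units; beyond the scatter). Compound 1 sits at the limit of > 10000 nM in this assay, at which 1 of the 3 values shown sits. The other measured steps, an at least 42-fold lower number from compound 1 to compound 2 (1.62 log units; beyond the scatter) and an at least 130-fold lower number from compound 1 to compound 3 (2.13 log units; beyond the scatter), likewise change only the group on the oxygen on the aromatic ring.

Compound 4, `COc1ccc(C(=O)N2CCC(n3cncc3-c3ccc(OS(=O)(=O)c4cccc(C#N)c4)cc3)CC2)cc1`, has not yet been measured. It differs from compound 3 in another place: 4-methoxyphenyl in place of 4-chloro-3-(trifluoromethyl)phenyl on a carbonyl carbon. Among the measured compounds shown here, none of the measured steps touch this part of the molecule, which is shared by all three measured compounds, so no measured step bears directly on it. On this basis the author expects, for the step from compound 3 to compound 4, a 4.1-fold higher number from compound 3 to compound 4 (0.61 log units; beyond the scatter), a change that is expected to stay near the scatter or weaken inhibition somewhat. The estimate for compound 4 in this assay is 300 nM, expected to lie between 60 nM and 2500 nM.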

Compound 4, half-maximal inhibitory concentration: 312 nM
Compound 4: the middle estimate sits 1.0-fold (0.02 log units) below what was measured; low and high end bracket the measured number.
By their numbers in this assay, from the lowest: compound 3; then compounds 2 and 4 (each within the scatter of the next). At a limit, above all of these: compound 1.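

In this assay, the group on the carbonyl carbon, shared by all three earlier compounds, turns out to affect inhibition: 4-methoxyphenyl in place of 4-chloro-3-(trifluoromethyl)phenyl brings a 4.3-fold higher number from compound 3 to compound 4 (0.63 log units; beyond the scatter), a step beyond the scatter. The position therefore accepts a quite different aryl group with only a modest change in the number, and compound 4 still gives a measured value rather than a limit of the assay. The change removes chlorine and fluorine and adds an oxygen, but nothing shown explains which of these differences drives the step.

The compounds shown leave open how a plain phenyl, a cyclohexyl or a 4-(dimethylamino)phenyl group would behave on this carbonyl carbon. On these data alone, it also remains open whether this step would be the same size with the thiophen-2-yl group on the sulfonyl sulfur.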